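Nitrile for fluorine on the N-aryl ring of a pyrazole amide

A few compounds are considered here, and "the series" means these few. Any claim that something is new, unique, unknown or untested is made for them only; others in the source may bear on it.

Of the compounds shown here, two have been measured in a functional assay on cells for positive allosteric modulation of metabotropic glutamate receptor 5 (Rattus norvegicus), read by calcium flux; a higher number here means that more compound is needed for the effect, a lower number that less compound is needed. Compound 1 `COc1ccc(C(=O)Nc2cc(-c3ccccc3)nn2-c2ccccc2)cc1` gives 54 nM in this assay. Compound 2 `O=C(Nc1cc(-c2ccccc2)nn1-c1ccccc1F)c1ccccc1` gives 104 nM in this assay; this is the higher of the two numbers, but the gap to compound 1 lies within the scatter, so the two cannot be told apart.

Compound 3 `N#Cc1cccc(-n2nc(-c3ccccc3)cc2NC(=O)c2ccccc2)c1` differs from compound 2 in one place: 3-cyanophenyl in place of 2-fluorophenyl on an aromatic nitrogen. The change sits on an aromatic nitrogen of the five-membered ring, next to the ring nitrogen and next to the ring atom that bears the benzamido group. Within the data shown here, no measured pair shows what such a change does here, so no direction can be drawn from the data; the step is expected to be small, either way or none beyond the scatter, as a 1.2-fold higher number from compound 2 to compound 3 (0.06 log units; within the scatter). Compound 3 is therefore estimated at 120 nM, with a range from 35 nM to 400 nM.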

Compound 3, half-maximal effective concentration: 117 nM
For compound 3 the middle estimate is 1.0-fold (0.01 log units) above the measured one; measured number inside the range.
By their numbers in this assay, from the lowest: compounds 1, 2 and 3 (each within the scatter of the next, the first and the last beyond it).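

In this assay, among these compounds, 3-cyanophenyl in place of 2-fluorophenyl on the aromatic nitrogen gives a 1.1-fold higher number from compound 2 to compound 3 (0.05 log units; within the scatter) and so provides the first measured pair at this position. The two compounds cannot be told apart, which shows that this position accepts either of these two substituted phenyl groups, with a nitrile entering and a fluorine leaving, without a readable difference in this assay. Nothing measured here offers an explanation for this result.

Going by these compounds, because the pair changes both the substituent and its place on the phenyl ring, it remains open which of the two matters, if either does. On these data alone, it also remains open whether this position would accept a carboxylic acid or an amine on that ring, or a cyclohexyl group in place of the ring itself.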